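This account rests on a few compounds, and the source may have more. Where it says the series, first, only, none or still open, it means among the compounds named here.

Compound 3 `CC(C)c1n[nH]c2c(NCc3ccc(-c4ccccn4)cc3)nc(SC(CO)C(C)C)nc12` stands with the highest number of the three measured in a functional assay on HT cells (Homo sapiens) for antiproliferative activity, read by fluorescence, with a stated time of 72 h (a lower number here means a stronger inhibitor of growth, a higher number a weaker inhibitor of growth), where compound 3 gives 980 nM. The step of a 16-fold higher number from compound 2 to compound 3 (1.20 log units; beyond the scatter) was large, and the step of a 3.0-fold higher number from compound 1 to compound 3 (0.47 log units; beyond the scatter) was modest, so what sits on the sulfur clearly shifts the result. Compound 4 `CC(C)c1n[nH]c2c(NCc3ccc(-c4ccccn4)cc3)nc(SCC(N)=O)nc12` keeps the rest of the structure and carries the change (carbamoylmethyl in place of 1-(hydroxymethyl)-2-methylpropyl on a sulfur). Compound 2 `CC(O)CSc1nc(NCc2ccc(-c3ccccn3)cc2)c2[nH]nc(C(C)C)c2n1`, with 2-hydroxypropyl on the sulfur, gives 62 nM, and compound 1 `CC(C)c1n[nH]c2c(NCc3ccc(-c4ccccn4)cc3)nc(SCC(O)CN3CCNCC3)nc12`, with 2-hydroxy-3-(piperazin-1-yl)propyl there, gives 332 nM. Both other groups on the sulfur sit at lower numbers than compound 3, so a return towards them is expected. Compound 4 is therefore estimated at 150 nM, within a range of 50 nM to 500 nM. That estimate means an expected step of a 6.5-fold lower number from compound 3 to compound 4 (0.82 log units; beyond the scatter).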

Compound 4, concentration for 50% growth inhibition: 192 nM
Compound 4: the middle estimate sits 1.3-fold (0.11 log units) below what was measured; the range from low to high includes it.
By their numbers in this assay, from the lowest: compound 2; then compounds 4 and 1 (each within the scatter of the next); then compound 3.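

In this assay, a group on the sulfur with no hydroxyl can still perform well: carbamoylmethyl recovers much of the ground lost with the bulkier group (a 5.1-fold lower number from compound 3 to compound 4 (0.71 log units; beyond the scatter)), though it does not reach 2-hydroxypropyl (a 3.1-fold higher number from compound 2 to compound 4 (0.49 log units; beyond the scatter)). The far larger piperazine-bearing chain offers no measurable advantage over carbamoylmethyl (a 1.7-fold lower number from compound 1 to compound 4 (0.24 log units; within the scatter)). Nothing available here explains these differences. Still open, from the compounds shown here alone, is how a carboxylic acid in place of the amide would behave, and whether a longer chain carrying the same amide would move the number.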